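Fluoro to methyl in a cytotoxicity series

The source may hold more compounds than are shown below. What is called first, only, known or untested is meant among the compounds shown, and "the series" means these compounds.

compound 1 (`O=c1cc(-c2ccccc2)oc2c(-c3cccc(F)c3)c(O)c(O)c(O)c12`) gives > 100000 nM as a limit
compound 2 (`Oc1cc2oc(-c3ccccc3)cc(=S)c2c(O)c1O`) gives > 100000 nM as a limit

Both entries come from a toxicity assay on Huh-7 cells (Homo sapiens) for cytotoxicity, read by CCK-8 assay, with a stated time of 24 h (on this read-out lower numbers stand for higher toxicity in this test and higher numbers for lower toxicity in this test), and neither is a number. Compound 1 stands at the limit of > 100000 nM in this assay, at which 2 of the 2 values shown sit, and so has no exact value to serve as a starting point. Compound 2 offers no listed step from compound 1, and the two entries show only the same limit.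

The next compound to be tested is compound 3 (`Cc1cccc(-c2c(O)c(O)c(O)c3c(=O)cc(-c4ccccc4)oc23)c1`). It keeps the core of compound 1 and carries methyl in place of fluoro on an aromatic carbon, meta to a large group (methyl in place of fluoro on an aromatic carbon), which turns 3-fluorophenyl into 3-methylphenyl.

Within the data shown here, no step between measured compounds is available for comparison. No step beyond the scatter is expected in this assay, in either direction, because compound 1 gives > 100000 nM as a limit of the assay. The estimated a number no higher from compound 1 to compound 3 (the limit leaves the size open) is therefore treated as no real change. For compound 3 the expected value is 100000 nM with an estimated range from 50000 nM to 200000 nM and a report of only a limit is the likeliest outcome.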

Compound 3, half-maximal cytotoxic concentration: > 100000 nM
Compound 3: only a limit was reported; the forecaster's own chance of this, stated with the estimate: 85%; the middle value sits exactly at the limit.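

No step can be read from compound 1 to compound 3 in this assay, because both entries are limits and not numbers: the limit of > 100000 nM in this assay, at which 3 of the 3 values shown sit.

The compounds shown leave open whether methyl in place of fluoro changes the half-maximal cytotoxic concentration at all, as none of them has an exact value in this assay.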